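Swapping an indolyl amine for a methoxyphenyl amine

The source may report more compounds than this note shows. Statements on the series, on what has been measured and on what is new or still open speak of the compounds shown alone.

Of the compounds shown here, two have been measured in a functional assay on B16-F10 cells (Mus musculus) for cytotoxicity, read by MTT assay, with a stated time of 48 h (a higher number here means a weaker inhibitor, a lower number a stronger inhibitor), so far. Compound 1 `COc1ccc(N/C=C\C(=O)c2nc(-c3ccc(F)cc3)n3ccccc23)cc1` gives 2560 nM in this assay. Within the data shown here, compound 2 `O=C(/C=C\Nc1ccc2[nH]ccc2c1)c1nc(-c2ccc(C(F)(F)F)cc2)n2ccccc12` gives 18200 nM in this assay, the highest of the two numbers; its only neighbour is compound 1, whose number is lower by a margin beyond the usual scatter. Compound 3 `COc1ccc(N/C=C\C(=O)c2nc(-c3ccc(C(F)(F)F)cc3)n3ccccc23)cc1` has not yet been measured. It differs from compound 2 in one place: 4-methoxyphenyl in place of 1H-indol-5-yl on an amine nitrogen. Among the measured compounds shown here, compound 3 thus carries the (4-methoxyphenyl)amino group that compound 1 also carries, while keeping the trifluoromethylphenyl group of compound 2; compound 1 and compound 3 differ only in the substituent on that phenyl ring, and no step between them has been measured. Given that compound 1, with the same amine group, shows 2560 nM, the step from compound 2 to compound 3 is expected to be a substantial fall in the number, beyond the scatter, of about a 3.6-fold lower number from compound 2 to compound 3 (0.56 log units; beyond the scatter). Compound 3 is therefore estimated at 5000 nM in this assay, with a likely range from 1500 nM to 15000 nM.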

Compound 3, half-maximal inhibitory concentration: > 30000 nM
Compound 3 gave a limit, no number; the forecaster's own chance of this, stated with the estimate: 5%; at least 6.0-fold (0.77 log units) between middle value and limit.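

In this assay compound 3 gives > 30000 nM, which is a limit of the assay and not a number. With the (4-methoxyphenyl)amino group held constant, trifluoromethyl in place of fluoro on an aromatic carbon gives a large step, an at least 11-fold higher number from compound 1 to compound 3 (1.06 log units; beyond the scatter), so carrying this amine group does not by itself keep the number in the range of compound 1. At the amine nitrogen, 4-methoxyphenyl in place of 1H-indol-5-yl gives an at least 1.6-fold higher number from compound 2 to compound 3 (0.21 log units; that floor lies within the scatter), so this change shows no firm gain in potency and only a floor that does not clear the scatter, the true size of the step remaining unknown: the limit of > 30000 nM in this assay, at which 1 of the 3 values shown sits.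

On these data alone, how far the true value of compound 3 lies past its limit remains open, and with it the size of both steps. Also open, as far as these compounds go, is whether the 1H-indol-5-yl amine paired with fluoro would behave like the 4-methoxyphenyl amine, and whether a chloro, methoxy or nitrile group on that aromatic carbon would give a number nearer that of compound 1 or of compound 3.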